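The source may report more compounds than this note shows. Statements on the series, on what has been measured and on what is new or still open speak of the compounds shown alone.

In an ADME assay on KB cells (Homo sapiens) for cytotoxicity, read by MTT assay, with a stated time of 72 h (a higher number here means that more compound is tolerated, a lower number that less compound is tolerated), three compounds sharing one core have been measured. Compound 1 `Clc1ccc(Nc2nc(-c3ccccn3)cs2)nc1`, with hydrogen at the site of interest, gives 98600 nM. Compound 2 `COc1ccc(-c2csc(Nc3ccc(Cl)cn3)n2)nc1`, with methoxy there, gives 59600 nM, and compound 3 `FC(F)(F)c1ccc(-c2csc(Nc3ccc(Cl)cn3)n2)nc1`, with trifluoromethyl, gives 35400 nM. Compound 3 stands apart from compound 1 beyond the scatter, with a 2.8-fold lower number from compound 1 to compound 3 (0.44 log units; beyond the scatter), a modest step. It does not stand apart from compound 2, with a 1.7-fold lower number from compound 2 to compound 3 (0.23 log units; within the scatter).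

Compound 4 `CCOc1ccc(-c2csc(Nc3ccc(Cl)cn3)n2)nc1` is the next case, with ethoxy in place of the trifluoromethyl of compound 3: ethoxy in place of trifluoromethyl on an aromatic carbon. Among the measured groups, methoxy is the closest to ethoxy, so compound 2 at 59600 nM is the main guide. Adding methoxy to the core made little measurable difference, with a 1.7-fold lower number from compound 1 to compound 2 (0.22 log units; within the scatter), which suggests that the corresponding ethoxy compound should lie in the same region. Going by the values given here, no ethoxy compound has been measured yet, however, so this remains an extrapolation. The expected move is upward but is not expected to exceed the scatter, and the estimate is a 1.6-fold higher number from compound 3 to compound 4 (0.19 log units; within the scatter). Compound 4 is therefore expected at about 55000 nM, with an estimated range of 27000 nM to 105000 nM.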

Compound 4, half-maximal cytotoxic concentration: 2700 nM
Beside the measured number, compound 4's estimate is 20-fold (1.31 log units) above it; the measured number lies below the stated range.
By their numbers in this assay, from the lowest: compound 4; then compounds 3, 2 and 1 (each within the scatter of the next, the first and the last beyond it).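

The position had so far shown little range, since moving from hydrogen through methoxy to trifluoromethyl spanned only a 2.8-fold lower number from compound 1 to compound 3 (0.44 log units; beyond the scatter), yet a single added carbon on the alkoxy chain brings a 22-fold lower number from compound 2 to compound 4 (1.34 log units; beyond the scatter). The result therefore shows that this position can respond sharply to a small change, and that methoxy is a poor stand-in for ethoxy here. Ethoxy also separates clearly from the other two groups, with a 13-fold lower number from compound 3 to compound 4 (1.12 log units; beyond the scatter) and a 37-fold lower number from compound 1 to compound 4 (1.56 log units; beyond the scatter), which leaves compound 4 as the least tolerated of the four and the only one far from the rest; nothing available here accounts for this jump.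

The compounds shown leave open whether a longer chain such as propoxy or a branched one such as isopropoxy would lower the number further or raise it again, and whether the oxygen is needed at all, a question that an ethyl group or an ethylamino group at this place would address. From the compounds shown here alone, it also remains open whether ethoxy would give a similar step at another place on the shared core.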